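Compound 1 to compound 3: heptyl in place of methoxy

A few compounds are considered here, and "the series" means these few. Any claim that something is new, unique, unknown or untested is made for them only; others in the source may bear on it.

Measured in a functional assay on HeLa cells (Homo sapiens) for cytotoxicity, read by WST assay, with a stated time of 48 h; on this read-out higher numbers stand for weaker inhibition and lower numbers for stronger inhibition:
- compound 1 `COC[C@H](C(C)C)C(c1ccc(O)c(OC)c1)c1ccc(O)c(OC)c1` gives 76000 nM
- compound 2 `COc1cc(C(c2ccc(O)c(OC)c2)[C@@H](CO)C(C)C)ccc1O` gives > 100000 nM (a limit of the assay, not a number)

For the measured compounds named here, compound 1 carries the only true number in this small set, and nothing measured yet lies on its lower side. Compound 2 reports > 100000 nM, which is a limit only.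

Compound 3 `CCCCCCCC[C@H](C(C)C)C(c1ccc(O)c(OC)c1)c1ccc(O)c(OC)c1` has not been measured. Its difference from compound 1 is heptyl in place of methoxy on a saturated chain carbon, three bonds along the chain from two aromatic carbons.

Going by the values given here, the one measured step on this side chain is an at least 1.3-fold higher number from compound 1 to compound 2 (0.11 log units; that floor lies within the scatter), where 1-(hydroxymethyl)-2-methylpropyl stands in place of 1-(methoxymethyl)-2-methylpropyl. Among the compounds with values here, no measured step brings in a long hydrocarbon chain, so the evidence on size is thin. A modest move toward stronger inhibition in this assay is therefore expected only tentatively, and no change remains plausible. The expected size is a 2.2-fold lower number from compound 1 to compound 3 (0.34 log units; beyond the scatter) as a rough estimate. The expected value for compound 3 is 35000 nM, with an estimated range from 10000 nM to 100000 nM in the measurement to come.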

Compound 3, half-maximal inhibitory concentration: 3100 nM
Estimate against measurement, compound 3: 11-fold (1.05 log units) above, outside the stated range (below it).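

In this assay, this position on the side chain turns out to respond strongly to what it carries: the change to heptyl in place of methoxy gives a 25-fold lower number from compound 1 to compound 3 (1.39 log units; beyond the scatter). The earlier step on the same side chain, an at least 1.3-fold higher number from compound 1 to compound 2 (0.11 log units; that floor lies within the scatter), rests on a limit and so gave no sign of how far a change here can move the number. Compound 3 now shows that a saturated chain carbon, three bonds along the chain from two aromatic carbons, can hold a long hydrocarbon chain with stronger inhibition in this read-out, although a single compound shows no trend with length.

The step replaces an oxygen-bearing group with an all-carbon chain and also lengthens the substituent, so these two differences remain inseparable; a propyl chain, a longer chain such as decyl, or an octyl chain ending in an amine or a carboxylic acid would bear on that question. The place of compound 2 relative to compound 1 also stays open, as compound 2 gives a limit and not a number: the limit of > 100000 nM in this assay, at which 1 of the 3 values shown sits.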